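Thiocarbamoyl substitution on the ring nitrogen of compound 1

The source may report more compounds than this note shows. Statements on the series, on what has been measured and on what is new or still open speak of the compounds shown alone.

Measured compounds:
compound 1, `Cn1cccc1-c1cc(-c2ccc(Br)cc2)[nH]c(=O)c1C#N`, 57500 nM
compound 2, `COc1ccc(-c2cc(-c3cccs3)[nH]c(=O)c2C#N)cc1`, 22400 nM

In a functional assay on RPMI-8226 cells (Homo sapiens) for cytotoxicity, read by sulforhodamine B assay, with a stated time of 48 h (on this read-out lower numbers stand for stronger inhibition of growth and higher numbers for weaker inhibition of growth), compound 1 gives 57500 nM, the highest of the two numbers available. Compound 2 gives 22400 nM, a lower number that lies beyond the scatter of this assay. The two compounds differ in more than one place, so no single step can be read from them.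

Compound 3, `Cn1cccc1-c1cc(-c2ccc(Br)cc2)n(C(=S)Nc2ccc(F)cc2)c(=O)c1C#N`, is not yet measured. It differs from compound 1 by a group of 10 heavy atoms (7 carbon, 1 nitrogen, 1 fluorine, 1 sulfur; one six-membered aromatic ring of carbon only) in place of a hydrogen atom, on an aromatic nitrogen. For the measured compounds named here, no measured pair shows this change, so its effect in this assay is unknown. A modest step is expected, either direction, not far beyond the scatter; the estimated step of a 1.9-fold lower number from compound 1 to compound 3 (0.28 log units; within the scatter) is only slightly downward. Compound 3 is expected to give 30000 nM, within a range from 8000 nM to 120000 nM.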

Compound 3, concentration for 50% growth inhibition: > 100000 nM
Compound 3 was reported as a limit; the forecaster's own chance of this, stated with the estimate: 10%; at least 3.3-fold (0.52 log units) between middle value and limit.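

In this assay compound 3 is reported only as a limit of the assay: the limit of > 100000 nM in this assay, at which 1 of the 3 values shown sits.

Placing the thiocarbamoyl group on the aromatic nitrogen in place of the hydrogen atom gives an at least 1.7-fold higher number from compound 1 to compound 3 (0.24 log units; that floor lies within the scatter), the first step that can be read at this position. From the compounds shown here alone, the true size of the step stays unknown, yet this large group on the ring nitrogen brings no stronger inhibition of growth in this pair.

The compounds shown leave open whether a methyl or an acetyl group on the same nitrogen would give a number closer to that of the core with its hydrogen atom. They also leave open whether the sulfur matters, which a carbamoyl group with oxygen in its place would test, and whether the fluorine on the aromatic ring plays any part.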